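The compounds below may be only part of what the source reports. "The series", "measured", "known", "first", "only" and "open" are said of these compounds alone.

Measured so far in a functional assay for antagonist activity at transient receptor potential cation channel subfamily V member 1 (Homo sapiens), read by FLIPR; on this read-out higher numbers stand for weaker inhibition and lower numbers for stronger inhibition: compound 1 `CC(C)(C)c1ccc(NC(=O)c2ccc(-c3ccccn3)cc2)cc1` gives 11 nM; compound 2 `CC(C)(C)c1ccc(NC(=O)c2ccc(-c3ncccc3NS(C)(=O)=O)cc2)cc1` gives 152 nM; compound 3 `CCS(=O)(=O)Nc1cccnc1-c1ccc(C(=O)Nc2ccc(C(C)(C)C)cc2)cc1` gives 49 nM.

Compound 3 holds the second highest of the three numbers; compound 2 is nearest, and compound 1 is furthest. Compound 4 `CC(C)(C)c1ccc(NC(=O)c2ccc(-c3ncccc3C(=N)N)cc2)cc1` differs from compound 3 by a group of 3 heavy atoms (1 carbon, 2 nitrogen; no ring) in place of a group of 6 heavy atoms (2 carbon, 1 nitrogen, 2 oxygen, 1 sulfur; no ring), on an aromatic carbon, the new group being one of 1 carbon and 2 nitrogen that sits ortho to a large group, two atoms from the ring nitrogen. Within the data shown here, the steps that bear on this are a 4.5-fold higher number from compound 1 to compound 3 (0.65 log units; beyond the scatter) and a 14-fold higher number from compound 1 to compound 2 (1.14 log units; beyond the scatter), both showing that a group at this position raised the number, and a 3.1-fold lower number from compound 2 to compound 3 (0.49 log units; beyond the scatter). Among the measured compounds shown here, no measured step introduces a group like this one, so the estimate is uncertain and is expected to land around a 6.1-fold higher number from compound 3 to compound 4 (0.79 log units; beyond the scatter). Compound 4 is thus expected to give 300 nM, within 50 nM to 2000 nM in this assay.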

Compound 4, half-maximal inhibitory concentration: > 4000 nM
Compound 4: only a limit was reported; the forecaster's own chance of this, stated with the estimate: 15%; middle value at least 13-fold (1.12 log units) from the limit.
By their numbers in this assay, from the lowest: compound 1; then compound 3; then compound 2. At a limit, above all of these: compound 4.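

In this assay compound 4 gives only a limit, not a number: the limit of > 4000 nM in this assay, at which 1 of the 4 values shown sits. The earlier compounds shown here showed that this position accepts (ethylsulfonyl)amino and methanesulfonamido at a modest to large cost, but this new group costs far more, with an at least 81-fold higher number from compound 3 to compound 4 (1.91 log units; beyond the scatter) and an at least 26-fold higher number from compound 2 to compound 4 (1.42 log units; beyond the scatter). Against compound 1, which carries hydrogen here, the change is an at least 360-fold higher number from compound 1 to compound 4 (2.56 log units; beyond the scatter), so the identity of the group matters, not just the presence of one. Still open, on these data alone, is how an amine or a carboxylic acid would fare at this position.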